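A Dimethylamino Analogue Weighed Against Three Assay Limits

The source may hold more compounds than are shown below. What is called first, only, known or untested is meant among the compounds shown, and "the series" means these compounds.

Compound 2 `Cc1ncn2c(S)nncc12` stands only at a limit: in a functional assay for inhibition, with Homo sapiens as the target (a lower number here means a stronger inhibitor, a higher number a weaker inhibitor), compound 2 gives > 48000 nM, which is a limit of the assay and not a number. Compound 1 `CNc1nncc2c(C)ncn12` likewise gives in this assay > 48000 nM, a limit. Compound 3 `CCCc1ncn2c(S)nncc12` gives in this assay > 48000 nM, also a limit. Compound 4 `Cc1ncn2c(N(C)C)nncc12` differs from compound 2 as follows: dimethylamino in place of sulfanyl on an aromatic carbon. Going by the values given here, the steps that bear on it, a step that the two limits leave unreadable from compound 1 to compound 2 and a step that the two limits leave unreadable from compound 2 to compound 3, cannot be sized, since (the limit of > 48000 nM in this assay, at which 3 of the 3 values shown sit). No readable step therefore guides the expectation, and compound 4 is expected to remain near that limit, with an estimate of 60000 nM within 15000 nM to 250000 nM. The step that the limit leaves unreadable from compound 2 to compound 4 is thus estimated as no change beyond the scatter.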

Compound 4, half-maximal inhibitory concentration: > 48000 nM
Compound 4 was reported as a limit; the forecaster's own chance of this, stated with the estimate: 80%; the middle value does not contradict the limit.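

Compound 4, like compound 1 and compound 2, stands only at a limit in this assay, so neither new step to compound 4 can be read: the limit of > 48000 nM in this assay, at which 4 of the 4 values shown sit. The compounds shown leave open how strongly any of them inhibits, and whether any change on the shared core would give a readable value.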